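The compounds below may be only part of what the source reports. "The series", "measured", "known", "first", "only" and "open" are said of these compounds alone.

Compound 2 `c1ccc(NCc2ccc(CNc3ncccn3)cc2)cc1` holds the higher of the two numbers recorded so far: in a functional assay on MDA-MB-231 cells for antagonist activity at C-X-C chemokine receptor type 4 (Homo sapiens), tested at 100 nM (a lower number here means a weaker effect, a higher number a stronger effect of the compound at the concentration tested), compound 2 gives 100%. Among the measured compounds shown here, the only other measured compound, compound 1 `c1ccc(NCc2ccc(CNc3ccccc3)cc2)cc1`, gives 64% in this assay. For the measured compounds named here, the single measured step, a number 36 percentage points higher from compound 1 to compound 2 (beyond the scatter), is a gain far beyond the scatter and came with pyrimidin-2-yl in place of phenyl on an amine nitrogen. Compound 3 `c1ccc(NCc2ccc(CNc3ncccn3)cc2)nc1` is reached from compound 2 by a related exchange: pyridin-2-yl in place of phenyl on an amine nitrogen. Going by the values given here, no measured step covers exactly this change; the one that exists shows that bringing a ring with a hetero atom onto an amine nitrogen gave a large rise. Compound 2 already sits at the top of the scale in this assay, so little room for a further rise remains, and the effect is expected to stay roughly where it is. For compound 3 the expected step is a number 8 percentage points lower from compound 2 to compound 3 (within the scatter). Compound 3 is therefore estimated at 92%, within a range of 72% to 100%.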

Compound 3, a percentage reported as inhibition, at one concentration (the size of the read-out at that concentration, not a potency): 64%
The estimate for compound 3 lay 28 percentage points above the measured number; the measured number lies below the stated range.
By their numbers in this assay, from the lowest: compounds 1 and 3 (each within the scatter of the next); then compound 2.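

At this amine nitrogen, with pyrimidin-2-yl kept on the other side of the molecule, the exchange of phenyl for pyridin-2-yl costs effect in this assay: there is a large drop, a number 36 percentage points lower from compound 2 to compound 3 (beyond the scatter). The earlier step, a number 36 percentage points higher from compound 1 to compound 2 (beyond the scatter), went the other way, so bringing a ring with a hetero atom onto an amine nitrogen is not a gain in itself; the outcome differs between these two exchanges, which involve different rings at different amine nitrogens. No measurement here explains the drop.

On these data alone, how pyridin-3-yl, pyridin-4-yl or a saturated ring such as cyclohexyl would read at this amine nitrogen remains open. So does whether the position of the ring nitrogen or the ring itself decides the outcome.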